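This account rests on a few compounds, and the source may have more. Where it says the series, first, only, none or still open, it means among the compounds named here.

Three compounds share one core and differ only in the chain attached to its ring oxygen; all three have been tested in an assay on cells with melanin-concentrating hormone receptor 1 (Homo sapiens) as the target, read by radioligand binding; a lower number here means a stronger inhibitor, a higher number a weaker inhibitor. Compound 1 `CCC(C)COc1cccc2ccc(N)nc12` carries a sec-butyl chain, and in this assay compound 1 gives 36 nM. Compound 2 `CC1CC1COc1cccc2ccc(N)nc12` carries a 2-methylcyclopropyl group, and in this assay compound 2 gives 1640 nM. Compound 3 `CCCCOc1cccc2ccc(N)nc12` carries an unbranched chain, and in this assay compound 3 gives 789 nM, which places it second highest of the three, closer to compound 2 than to compound 1. The step of a 22-fold higher number from compound 1 to compound 3 (1.34 log units; beyond the scatter) shows how much a single methyl on the chain can matter, while a 46-fold higher number from compound 1 to compound 2 (1.66 log units; beyond the scatter) and a 2.1-fold lower number from compound 2 to compound 3 (0.32 log units; beyond the scatter) show the two branched chains standing far apart from each other.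

Compound 4 `COC(C)(C)CCOc1cccc2ccc(N)nc12` arises from compound 3 by the change (1-methoxy-1-methylethyl in place of ethyl on a saturated chain carbon, two bonds along the chain from an oxygen on an aromatic ring). Among the measured compounds shown here, no measured step covers an added oxygen in the chain. The nearest guide is a 22-fold higher number from compound 1 to compound 3 (1.34 log units; beyond the scatter), where a methyl on the chain made a large difference, though here the new branching sits further out and brings an acceptor. A moderate gain is therefore expected, with wide uncertainty. Compound 4 is estimated at 300 nM in this assay, within 60 nM to 1500 nM. That estimate means an expected step of a 2.6-fold lower number from compound 3 to compound 4 (0.42 log units; beyond the scatter).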

Compound 4, half-maximal inhibitory concentration: 132 nM
Estimate against measurement, compound 4: 2.3-fold (0.36 log units) above; low and high end bracket the measured number.
By their numbers in this assay, from the lowest: compound 1; then compound 4; then compound 3; then compound 2.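

Among the compounds shown here, until this result, the only gain over the unbranched chain of compound 3 came from the sec-butyl chain of compound 1. In this assay, putting 1-methoxy-1-methylethyl in place of ethyl, on a saturated chain carbon two bonds along the chain from an oxygen on an aromatic ring, also lowers the number (a 6.0-fold lower number from compound 3 to compound 4 (0.78 log units; beyond the scatter)), so a second, larger chain carrying an oxygen also gives a stronger inhibitor than the unbranched one. The same chain, read as 2-methoxy-2-methylpropyl, also stands well clear of the 2-methylcyclopropyl group (a 12-fold lower number from compound 2 to compound 4 (1.09 log units; beyond the scatter)) but does not match sec-butyl (a 3.7-fold higher number from compound 1 to compound 4 (0.56 log units; beyond the scatter)), so compound 1 keeps the lowest number of the four.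

Nothing measured here explains why these chains differ. On these data alone, it also stays open whether the gain belongs to the added oxygen or to the branching, a question that an all-carbon chain of the same shape, such as 3,3-dimethylpentyl, could help to settle, while a hydroxyl or an amine in place of the methoxy group would test what else this position tolerates.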